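Swapping pyridin-4-yl for phenyl on a shared core

The source may hold more compounds than are shown below. What is called first, only, known or untested is meant among the compounds shown, and "the series" means these compounds.

Values in a physicochemical assay for solubility, at pH 7 (on this read-out lower numbers stand for lower solubility and higher numbers for higher solubility), are as follows:
- Compound 1 `CN1CCC(C(=O)N2Cc3c(NC(=O)c4ccc(Cl)cc4)n[nH]c3C2(C)C)CC1` gives > 225000 nM as a limit
- Compound 2 `CN1CCC(C(=O)N2Cc3c(NC(=O)c4ccc(C(F)(F)F)cc4)n[nH]c3C2(C)C)CC1` gives 191000 nM as a number
- Compound 3 `CN1CCC(C(=O)N2Cc3c(NC(=O)c4ccncc4)n[nH]c3C2(C)C)CC1` gives > 225000 nM as a limit

Compound 3 stands at > 225000 nM as a limit of the assay, not a number. That limit recurs (the limit of > 225000 nM in this assay, at which 2 of the 3 values shown sit). Compound 4 `CN1CCC(C(=O)N2Cc3c(NC(=O)c4ccccc4)n[nH]c3C2(C)C)CC1` differs from compound 3 in one group, with phenyl in place of pyridin-4-yl on a carbonyl carbon.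

For the measured compounds named here, no measured step makes exactly this change. The nearest steps exchange pyridin-4-yl with 4-chlorophenyl or 4-(trifluoromethyl)phenyl at the same carbonyl carbon. One is an at least 1.1-fold higher number from compound 2 to compound 3 (0.07 log units; that floor lies within the scatter) and gives only a floor. The other is a step that the two limits leave unreadable from compound 1 to compound 3 and gives no size. The step between the two substituted compounds is an at least 1.1-fold lower number from compound 1 to compound 2 (0.07 log units; that floor lies within the scatter) and also stays a floor. None of these shows a move beyond the scatter, so no clear step in either direction is expected, and a reading near the limit is likely again. The expected change is a number no higher from compound 3 to compound 4 (the limit leaves the size open) in this assay and no more. For compound 4 the estimate is 225000 nM with an expected range of 130000 nM to 350000 nM (both ends estimated).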

Compound 4, solubility: > 225000 nM
Compound 4: no number, only a limit; the forecaster's own chance of this, stated with the estimate: 55%; the middle value lies on the limit itself.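

Removing the trifluoromethyl group, with hydrogen in its place on an aromatic carbon, gives an at least 1.1-fold higher number from compound 2 to compound 4 (0.07 log units; that floor lies within the scatter) in this assay. Both ends of the steps that link compound 4 to compound 3 and to compound 1 are limits, so those steps cannot be read, and pyridin-4-yl, 4-chlorophenyl and phenyl cannot be put in any order on this carbonyl carbon. What is new is that plain benzoyl, with carbon only in its ring and nothing added to that ring, sits at the same limit as (pyridin-4-yl)carbonyl, leaving compound 2 as the only compound here with a number: the limit of > 225000 nM in this assay, at which 3 of the 4 values shown sit.

Going by these compounds, how far these compounds differ beyond that limit stays unknown, as a limit gives no size. On these data alone, it is also open whether a larger group, such as tert-butyl or a longer alkyl chain, in place of chloro on the aromatic carbon would give a clear number and a step beyond the scatter.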